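The source may hold more compounds than are shown below. What is called first, only, known or untested is meant among the compounds shown, and "the series" means these compounds.

Compound 1, `CCc1ccc(N(CC2CCC2)S(=O)(=O)c2ccc3c(c2)C(=O)CC(C2CCOCC2)O3)cc1`: 4.1
Compound 2, `CC(C)CN(c1ccc(F)cc1F)S(=O)(=O)c1ccc2c(c1)C(=O)CC(C1CCOCC1)O2`: 3.62
Compound 3, `CCc1ccc(N(CC(C)C)S(=O)(=O)c2ccc3c(c2)C(=O)CC(C2CCN(C(=O)OC(C)(C)C)CC2)O3)cc1`: 5.1

Of the compounds shown here, three sharing one core have been measured in a physicochemical assay for lipophilicity, at pH 7.4; a higher number here means a more lipophilic compound, a lower number a more polar compound. Compound 1 gives 4.1 and stands second highest of the three. Compound 2, with 3.62, sits below it by a gap that is beyond the usual scatter. Compound 3, with 5.1, sits above compound 1 by a larger gap, also beyond the scatter. Going by the values given here, none of these three pairs differs in just one place, so no single measured step connects them.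

The next compound, compound 4, is `CCc1ccc(N(CC2CC2)S(=O)(=O)c2ccc3c(c2)C(=O)CC(C2CCOCC2)O3)cc1`. It differs from compound 1 in one place: cyclopropyl in place of cyclobutyl on a saturated chain carbon bound to a sulfonamide nitrogen. The group that leaves is cyclobutyl and the group that enters is cyclopropyl, on a saturated chain carbon bound to a sulfonamide nitrogen.

Among the compounds with values here, no measured pair shows this exact change, so the expectation rests on compound 1 alone. The step is expected to be small and downward, at the edge of the usual scatter, a number 0.40 log units lower from compound 1 to compound 4 (beyond the scatter) in this assay. Starting from compound 1 at 4.1, compound 4 is estimated to give 3.7, with a likely range from 3.3 to 4.1.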

Compound 4, distribution coefficient: 3.77
For compound 4 the middle estimate is 0.07 log units below the measured one; the range from low to high includes it.
By their numbers in this assay, from the lowest: compounds 2 and 4 (each within the scatter of the next); then compound 1; then compound 3.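

Measured in this assay, the swap of cyclobutyl for cyclopropyl on a saturated chain carbon bound to a sulfonamide nitrogen gives a number 0.33 log units lower from compound 1 to compound 4 (beyond the scatter), a modest step. Going by these compounds alone, this is the first step in the set in which a single place changes, and it shows that this position alone can move the number in this assay beyond the scatter, even though the leaving group has 4 heavy atoms and the entering group has 3, both all carbon and with no hydrogen-bond donors or acceptors. No separate measurement offers a reason for the size of this step.

This one pair cannot show whether the same swap would give a similar step on a different background, such as a compound carrying the other aromatic ring of compound 2 or the other saturated ring of compound 3. On these data alone, how this position would respond to a longer open chain, or to a chain ending in an amine or a carboxylic acid, also remains open.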